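A few compounds are considered here, and "the series" means these few. Any claim that something is new, unique, unknown or untested is made for them only; others in the source may bear on it.

Measured so far, in a functional assay on Bel-7402 cells (Homo sapiens) for inhibition, read by MTT assay, with a stated time of 24 h, tested at 10 ug/mL; a lower number here means less inhibition of growth, a higher number more inhibition of growth at the concentration tested:

Compound 1, `O=C(CCCCC1CCSS1)Nc1ccccn1`, gives 5.77%.
Compound 2, `O=C(CCCCC1CCSS1)Nc1ccc(Cl)cn1`, gives 16.1%.
Compound 3, `O=C(CCCCC(S)CCS)Nc1ccccc1`, gives 3.72%.

Compound 2 differs from compound 1 by chloro in place of hydrogen on an aromatic carbon, and that single change produced a number 10.3 percentage points higher from compound 1 to compound 2 (beyond the scatter). Compound 3 stands on a different core; how its core differs from that of compound 1 is not broken down here, and its value lies within the scatter of compound 1 while sitting further from compound 2.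

Compound 4, `O=C(CCCCC(S)CCS)Nc1cccc(Cl)c1`, differs from compound 3 by chloro in place of hydrogen on an aromatic carbon. This is the same kind of change as that from compound 1 to compound 2, but the surroundings differ: in compound 2 the chloro sits on a six-membered aromatic ring with one nitrogen, two atoms from the ring nitrogen and para to a large group, whereas in compound 4 it sits on a six-membered aromatic ring of carbon only, meta to a large group. A step similar to a number 10.3 percentage points higher from compound 1 to compound 2 (beyond the scatter) is therefore expected but less certain, giving an estimated a number 8.3 percentage points higher from compound 3 to compound 4 (within the scatter) for compound 4 in this assay. Compound 4 is thus expected to give about 12%, most likely between 3% and 22%.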

Compound 4, percent growth inhibition at one concentration: 3.22%
Compound 4: middle estimate off by 8.8 percentage points, on the high side, within the range that was stated.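

Chloro in place of hydrogen on an aromatic carbon gave a number 0.5 percentage points lower from compound 3 to compound 4 (within the scatter) in this assay. Set beside the step on the core of compound 1, this new step cannot be told apart from it: the same change on two cores in this assay, a number 10.3 percentage points higher (beyond the scatter) from compound 1 to compound 2 and a number 0.5 percentage points lower (within the scatter) from compound 3 to compound 4, 10.8 percentage points apart, within the scatter of two such steps. This shows neither that the change carries from one core to the other nor that it fails to, and with one pair on each core the rise seen for compound 2 stands alone in this series.

On these data alone, whether bromo or methoxy on the aromatic ring would behave as chloro does remains open. So does whether an amine, a carboxylic acid or a longer chain would shift the number on either core.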